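Swapping One Side Chain on a Shared Core

This account rests on a few compounds, and the source may have more. Where it says the series, first, only, none or still open, it means among the compounds named here.

Compound 1 `CN(C)CCCCCn1c2c(c3ccccc31)C(=O)c1c[n+]([O-])c3ccccc3c1C2=O` gives 70 nM in testing
Compound 2 `CC1(C)OC[C@H](Cn2cc(Cn3c4c(c5ccccc53)C(=O)c3c[n+]([O-])c5ccccc5c3C4=O)nn2)O1` gives 100 nM in testing

In a toxicity assay on HEK-293T cells (Homo sapiens) for cytotoxicity, read by MTT assay, with a stated time of 72 h (on this read-out lower numbers stand for stronger inhibition and higher numbers for weaker inhibition), compound 1 (70 nM) and compound 2 (100 nM) lie within the usual scatter of each other, so neither stands apart. Compound 3 `CN1CCN(CCCn2c3c(c4ccccc42)C(=O)c2c[n+]([O-])c4ccccc4c2C3=O)CC1` has not yet been measured. The change from compound 1 to compound 3 (4-methylpiperazin-1-yl in place of 2-(dimethylamino)ethyl on a saturated chain carbon, three bonds along the chain from an aromatic nitrogen) puts 4-methylpiperazin-1-yl in place of 2-(dimethylamino)ethyl on a saturated chain carbon, three bonds along the chain from an aromatic nitrogen. Going by the values given here, no measured pair isolates this change. Still, compound 2 (100 nM) carries a different substituent on the shared core and stays within the scatter of compound 1, so no step beyond the scatter is expected in this assay here. The estimated step is a 1.3-fold higher number from compound 1 to compound 3 (0.11 log units; within the scatter) and it is expected to stay within the scatter. Compound 3 is estimated at 90 nM with 35 nM to 250 nM as the expected range.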

Compound 3, half-maximal inhibitory concentration: 170 nM
The estimate for compound 3 lay 1.9-fold (0.28 log units) below the measured number, within the range that was stated.
By their numbers in this assay, from the lowest: compounds 1, 2 and 3 (each within the scatter of the next, the first and the last beyond it).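

In this assay, putting 4-methylpiperazin-1-yl in place of 2-(dimethylamino)ethyl on a saturated chain carbon, three bonds along the chain from an aromatic nitrogen, gives a 2.4-fold higher number from compound 1 to compound 3 (0.39 log units; beyond the scatter), a modest step and the only one here that can be read across a single change. Going by these compounds alone, it shows that this place on the side chain is not indifferent to the change, which the earlier values, with no such pair among them, could not show. Still open, from the compounds shown here alone, is whether the ring or the second nitrogen carries the step, and whether a morpholine or a piperidine at the end of the same chain would give a number closer to that of compound 1 or to that of compound 3. Nothing measured alongside these values bears on why the number moved.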